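This account rests on a few compounds, and the source may have more. Where it says the series, first, only, none or still open, it means among the compounds named here.

Measured so far:
Compound 1 `CC1=C(/C=C/C(=O)/C=C/c2ccc(Br)cc2)C(C)(C)CCC1`: 88800 nM
Compound 2 `CC1=C(/C=C/C(=O)/C=C/c2ccc(C#N)cc2)C(C)(C)CCC1`: 22200 nM
Compound 3 `CC1=C(/C=C/C(=O)/C=C/c2ccc([N+](=O)[O-])cc2)C(C)(C)CCC1`: 28700 nM

In a functional assay on HeLa cells (Homo sapiens) for cytotoxicity, read by sulforhodamine B assay, with a stated time of 48 h (a lower number here means a stronger inhibitor, a higher number a weaker inhibitor), compound 1 stands highest of the three, with compound 3 nearest and compound 2 furthest. The unmeasured compound 4 `CC1=C(/C=C/C(=O)/C=C/c2ccccc2Cl)C(C)(C)CCC1` differs from compound 1 by 2-chlorophenyl in place of 4-bromophenyl on a double-bonded chain carbon bound to a double-bonded chain carbon. Among the measured compounds shown here, no measured step swaps the whole aryl group this way; the nearest comparisons, a 4.0-fold lower number from compound 1 to compound 2 (0.60 log units; beyond the scatter) and a 3.1-fold lower number from compound 1 to compound 3 (0.49 log units; beyond the scatter), show that exchanging the bromo substituent moves the number only modestly. For the measured compounds named here, with no direct precedent, a step of at most modest size, if any, is expected from compound 1 to compound 4, and the estimate for compound 4 is 60000 nM, between 25000 nM and 150000 nM, meaning an expected 1.5-fold lower number from compound 1 to compound 4 (0.17 log units; within the scatter).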

Compound 4, half-maximal inhibitory concentration: 21800 nM
Compound 4: the middle estimate sits 2.8-fold (0.44 log units) above what was measured, and the stated range ends above it.
By their numbers in this assay, from the lowest: compounds 4, 2 and 3 (each within the scatter of the next); then compound 1.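

In this assay, 2-chlorophenyl in place of 4-bromophenyl gives a 4.1-fold lower number from compound 1 to compound 4 (0.61 log units; beyond the scatter), so this number also falls when the bromo group is not exchanged for cyano or nitro, but the whole aryl group is exchanged for one bearing a different halogen in a different place. Nothing available explains this step.

From the compounds shown here alone, the halogen and its place change together here, so their separate shares remain unknown. Going by these compounds, how an unsubstituted phenyl group, or an aryl group bearing an amine or a carboxylic acid, would behave also remains open.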